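Replacing an aromatic ring in compound 2

The source may report more compounds than this note shows. Statements on the series, on what has been measured and on what is new or still open speak of the compounds shown alone.

Compound 1 `CC(=O)N1CC[C@H](C(=O)N2CC[C@](c3ccc(C(OCc4c(F)cccc4F)(C(F)(F)F)C(F)(F)F)cc3)(S(=O)(=O)c3ccc(F)cc3)C2)C1`: 19%
Compound 2 `Cc1cccc(F)c1COC(c1ccc([C@]2(S(=O)(=O)c3ccc(F)cc3)CCN(C(=O)[C@H]3CC[C@H](C(=O)O)CC3)C2)cc1)(C(F)(F)F)C(F)(F)F`: 79%

In an ADME assay on microsomes from liver (Homo sapiens) for metabolic stability, with a stated time of 10 min (a lower number here means that less of the compound is left, a higher number that more of the compound is left), compound 1 stands at 19% and compound 2 stands highest of the two at 79%. The gap between these two compounds lies beyond the scatter. Compound 3 `O=C(O)[C@H]1CC[C@H](C(=O)N2CC[C@](c3ccc(C(OCC4CCCC4)(C(F)(F)F)C(F)(F)F)cc3)(S(=O)(=O)c3ccc(F)cc3)C2)CC1` keeps the rest of compound 2 and changes one group: cyclopentyl in place of 2-fluoro-6-methylphenyl on a saturated chain carbon bound to an oxygen on a saturated carbon. In words, this puts cyclopentyl in place of 2-fluoro-6-methylphenyl on a saturated chain carbon bound to an oxygen on a saturated carbon. Going by the values given here, no measured pair shows this change alone, and compound 1 and compound 2 differ in more than one place. With compound 2 at 79%, close to the top of the scale, a moderate fall is the expected direction, though a shift within the scatter remains possible. In this assay the estimated step is a number 17 percentage points lower from compound 2 to compound 3 (beyond the scatter). For compound 3 the expected value is 62%, with an estimated range of 35% to 85%.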

Compound 3, percent of the compound remaining: 73%
For compound 3 the middle estimate is 11 percentage points below the measured one; measured number inside the range.
By their numbers in this assay, from the lowest: compound 1; then compounds 3 and 2 (each within the scatter of the next).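

In this assay, putting cyclopentyl in place of 2-fluoro-6-methylphenyl gives a number 6 percentage points lower from compound 2 to compound 3 (within the scatter), so this read-out does not separate the two groups at this place. Going by these compounds alone, this is the first comparison here that differs in one place only, and it shows that an aromatic ring of 8 heavy atoms and a non-aromatic ring of 5 heavy atoms, both of carbon only, can stand here with no change beyond the scatter. Nothing measured here explains why the two groups read alike.

From the compounds shown here alone, whether a ring is needed here at all remains open, since a longer open chain or an amine at the same place might read differently. Going by these compounds, compound 1 differs from compound 2 in more than one place, so the source of its gap remains open too.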